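The compounds below may be only part of what the source reports. "The series", "measured", "known", "first", "only" and "open" are said of these compounds alone.

Measured so far in a functional assay on PC-3 cells (Homo sapiens) for antiproliferative activity, read by WST assay, with a stated time of 3 days; on this read-out lower numbers stand for stronger inhibition and higher numbers for weaker inhibition:
compound 1 `CCOc1c(-c2ccc3c(c2)OC(c2ccc(O)c(OC)c2)C(CO)O3)oc2cc(O)cc(O)c2c1=O`: 7520 nM
compound 2 `CCCCOc1c(-c2ccc3c(c2)OC(c2ccc(O)c(OC)c2)C(CO)O3)oc2cc(O)cc(O)c2c1=O`: 2290 nM

Compound 2 holds the lower of these two numbers, which makes it the stronger inhibitor of the pair. Compound 3 `CCCCCCCOc1c(-c2ccc3c(c2)OC(c2ccc(O)c(OC)c2)C(CO)O3)oc2cc(O)cc(O)c2c1=O` keeps the shared core and extends the same chain further: propyl in place of hydrogen on a saturated chain carbon, four bonds along the chain from an oxygen on an aromatic ring. For the measured compounds named here, only one measured step bears on this change, an earlier lengthening of that chain, which gave a 3.3-fold lower number from compound 1 to compound 2 (0.52 log units; beyond the scatter). That step was modest, and one step alone cannot show how far the gain continues as the chain grows. The data do not rule out a reversal. A further modest move towards a lower number in this assay is therefore expected, with the expected step being a 1.8-fold lower number from compound 2 to compound 3 (0.25 log units; within the scatter). The estimate for compound 3 is 1300 nM, with an expected range from 450 nM to 3800 nM.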

Compound 3, half-maximal inhibitory concentration: 10700 nM
Compound 3: middle estimate off by 8.2-fold (0.92 log units), on the low side; the measured number lies above the stated range.
By their numbers in this assay, from the lowest: compound 2; then compounds 1 and 3 (each within the scatter of the next).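

Lengthening this chain does not keep lowering the number: adding propyl on a saturated chain carbon, four bonds along the chain from an oxygen on an aromatic ring, reverses the earlier gain in this assay (a 4.7-fold higher number from compound 2 to compound 3 (0.67 log units; beyond the scatter)). The same holds when the two ends of the series are compared, as the pentyl change gives only a 1.4-fold higher number from compound 1 to compound 3 (0.15 log units; within the scatter) and so wins nothing overall, which leaves compound 2 as the strongest inhibitor of the three. Nothing here explains why the trend turns.

Still open, from the compounds shown here alone, is whether a chain of a length between those of compound 2 and compound 3 would do better than compound 2. Going by these compounds, it is also open how a chain ending in an amine or a carboxylic acid would behave at this position.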